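Methyl in place of chloro: notes on compounds 1 to 4

The source may report more compounds than this note shows. Statements on the series, on what has been measured and on what is new or still open speak of the compounds shown alone.

In a functional assay on IMR-32 cells (Homo sapiens) for cytotoxicity, read by MTT assay, tested at 60 ug/mL (on this read-out lower numbers stand for less inhibition and higher numbers for more inhibition at the one concentration tested (going by the name of the read-out)), the measured compounds stand as follows:
compound 1 `CC(C)NC(=O)CCC(NS(=O)(=O)c1cc(Cl)ccc1Cl)C(=O)NC(C)C` gives 16.7%
compound 2 `CCCCCCNC(=O)CCC(NS(=O)(=O)c1cc(Cl)ccc1Cl)C(=O)NCCCCCC` gives 12.4%
compound 3 `Cc1ccc(Cl)c(S(=O)(=O)NC(CCC(=O)NC(C)C)C(=O)NC(C)C)c1` gives 29.8%

Compound 1 and compound 2 differ in their cores; that difference is not broken down here. Compound 2 has the lowest of the three numbers, but against compound 1 the gap is within the scatter, so no order is claimed between them; against compound 3 the gap lies beyond the scatter.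

Going by the values given here, the one counted step is methyl in place of chloro on an aromatic carbon, which gave a number 13.1 percentage points higher from compound 1 to compound 3 (beyond the scatter).

Compound 4 `CCCCCCNC(=O)CCC(NS(=O)(=O)c1cc(C)ccc1Cl)C(=O)NCCCCCC` is compound 2 carrying the same change, (methyl in place of chloro on an aromatic carbon), at a place that reads the same as in the step above. Among the compounds with values here, with only one prior instance of this change, the expectation rests on that single step, a number 13.1 percentage points higher from compound 1 to compound 3 (beyond the scatter), applied to compound 2. The step from compound 2 to compound 4 in this assay is therefore expected to be a number 12.6 percentage points higher from compound 2 to compound 4 (beyond the scatter). Compound 4 is estimated at 25%, with a range from 13% to 38%.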

Compound 4, a percentage reported as inhibition, at one concentration (the size of the read-out at that concentration, not a potency): 11.3%
Compound 4: middle estimate off by 13.7 percentage points, on the high side; measured number below the stated range.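

In this assay, methyl in place of chloro now gives a number 1.1 percentage points lower from compound 2 to compound 4 (within the scatter), so the rise seen on the core of compound 1 does not reappear on the second core. Set side by side, the two steps differ, and a single number for this change does not carry from one core to the other in this series: the same change on two cores in this assay, a number 13.1 percentage points higher (beyond the scatter) from compound 1 to compound 3 and a number 1.1 percentage points lower (within the scatter) from compound 2 to compound 4, 14.2 percentage points apart, beyond the scatter of two such steps With only one step on each core, this shows that the size of the step depends on the core, but it does not show which feature of the cores sets the difference, nor how the step would behave on any third core.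

The compounds shown leave open how the change behaves on a core whose side chains end in an amine or a carboxylic acid, which would test whether the two steps mark the ends of a range. They also leave open whether another group at the same place on the ring, such as methoxy or a nitrile, would follow the pattern of methyl on each core.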